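The source may hold more compounds than are shown below. What is called first, only, known or untested is meant among the compounds shown, and "the series" means these compounds.

Of the compounds shown here, three sharing one core have been tested in an ADME assay on L929 cells (Mus musculus) for cytotoxicity, read by resazurin assay, with a stated time of 48 h; a higher number here means that more compound is tolerated, a lower number that less compound is tolerated. Compound 1 `COC(=O)CCn1c2ccc([N+](=O)[O-])cc2c(=O)n1Cc1ccccc1` gives > 256000 nM, which is a limit of the assay and not a number. Compound 2 `CCOC(=O)n1c2ccc([N+](=O)[O-])cc2c(=O)n1Cc1ccccc1` gives 122000 nM, and compound 3 `O=C(c1ccccc1)n1c2ccc([N+](=O)[O-])cc2c(=O)n1Cc1ccccc1` gives 146000 nM. These two numbers are level, since a 1.2-fold higher number from compound 2 to compound 3 (0.08 log units; within the scatter) stays within the scatter.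

Compound 4 `Cc1ccc(S(=O)(=O)n2c3ccc([N+](=O)[O-])cc3c(=O)n2Cc2ccccc2)cc1` carries (4-methylphenyl)sulfonyl in place of the benzoyl of compound 3 on an aromatic nitrogen ((4-methylphenyl)sulfonyl in place of benzoyl on an aromatic nitrogen). All measured steps are changes at this same nitrogen. Starting from the limit, they give an at least 2.0-fold lower number from compound 1 to compound 2 (0.32 log units; beyond the scatter) and an at least 1.7-fold lower number from compound 1 to compound 3 (0.24 log units; that floor lies within the scatter). The number-to-number step, a 1.2-fold higher number from compound 2 to compound 3 (0.08 log units; within the scatter), is the better guide, and it shows that exchanging ethoxy for phenyl on the carbonyl carbon moved little. For the measured compounds named here, no measured compound has a sulfonyl group on that nitrogen, so the expectation remains loose. The expected change is small and not beyond the scatter, namely a 1.2-fold lower number from compound 3 to compound 4 (0.09 log units; within the scatter). For compound 4 the estimated value is 120000 nM, with an expected range of 50000 nM to 256000 nM.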

Compound 4, concentration lethal to 50% of the cells: > 256000 nM
Compound 4: no number, only a limit; the forecaster's own chance of this, stated with the estimate: 15%; middle value at least 2.1-fold (0.32 log units) away from the limit.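

A sulfonyl group on this aromatic nitrogen is new to the series, and in this assay compound 4 gives > 256000 nM, which is a limit of the assay and not a number. Replacing the carbonyl groups with (4-methylphenyl)sulfonyl gives an at least 2.0-fold higher number from compound 2 to compound 4 (0.32 log units; beyond the scatter), a firm rise against ethoxycarbonyl, and an at least 1.7-fold higher number from compound 3 to compound 4 (0.24 log units; that floor lies within the scatter), which against benzoyl only points the same way without being firm. The step between compound 1 and compound 4 cannot be read, because both compounds stand at the limit: the limit of > 256000 nM in this assay, at which 2 of the 4 values shown sit.

On these data alone, how much more compound is tolerated beyond the limit in compound 4 stays open, so the true size of these rises is unknown. Also open, as far as these compounds go, is how an amine or a carboxylic acid on a longer chain at this nitrogen would behave.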